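The source may hold more compounds than are shown below. What is called first, only, known or untested is meant among the compounds shown, and "the series" means these compounds.

Compound 2, whose structure is `CN1CCN(CCCN(c2nc3cc(Cl)c(Cl)cc3[nH]2)[C@@H]2CC[C@]3(c4cccc(C#N)c4)C[C@@H]3C2)CC1`, gives 2.2 nM in an assay on isolated protein for binding affinity to melanin-concentrating hormone receptor 1 (Homo sapiens); on this read-out lower numbers stand for stronger inhibition and higher numbers for weaker inhibition. Compound 1, with the structure `CN1CCN(CCCN(c2nc3cc(F)c(F)cc3[nH]2)[C@@H]2CC[C@]3(c4cccc(C#N)c4)C[C@@H]3C2)CC1`, differs from it by 5,6-difluoro-1H-benzimidazol-2-yl in place of 5,6-dichloro-1H-benzimidazol-2-yl on an amine nitrogen; in this assay compound 1 gives 8.4 nM, and the change brings a 3.8-fold higher number from compound 2 to compound 1 (0.58 log units; beyond the scatter). Compound 3, whose structure is `CN1CCN(CCCN(c2nc3cc(Cl)c(Cl)cc3[nH]2)[C@@H]2CC[C@]3(c4cccc(C=O)c4)C[C@@H]3C2)CC1`, shares the core of compound 2 but carries formyl in place of cyano on an aromatic carbon; in this assay compound 3 gives 13.7 nM, and that change brings a 6.2-fold higher number from compound 2 to compound 3 (0.79 log units; beyond the scatter). Among the three measured compounds, compound 3 has the highest number, and its gap to compound 1 lies within the scatter, while its gap to compound 2 lies beyond it.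

Compound 4, whose structure is `CN1CCN(CCCN(c2nc3cc(F)c(F)cc3[nH]2)[C@@H]2CC[C@]3(c4cccc(C=O)c4)C[C@@H]3C2)CC1`, has not been measured in this assay. It differs from compound 3 by 5,6-difluoro-1H-benzimidazol-2-yl in place of 5,6-dichloro-1H-benzimidazol-2-yl on an amine nitrogen. This is the same change, made at the same place, as that from compound 2 to compound 1, and the two pairs differ from each other only in the core, by formyl in place of cyano on an aromatic carbon. The change occurs twice among the compounds shown.

If the change behaves on the core of compound 3 as it did on the core of compound 2, compound 4 is expected to give 50 nM in this assay. This expectation rests on the measured 3.8-fold higher number from compound 2 to compound 1 (0.58 log units; beyond the scatter). The step so expected is a 3.6-fold higher number from compound 3 to compound 4 (0.56 log units; beyond the scatter). Among the measured compounds shown here, with only one earlier instance of the change, the estimate for compound 4 is expected to lie between 20 nM and 130 nM.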

Compound 4, inhibition constant: 16.3 nM
For compound 4 the middle estimate is 3.1-fold (0.49 log units) above the measured one; measured number below the stated range.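

In this assay, 5,6-difluoro-1H-benzimidazol-2-yl in place of 5,6-dichloro-1H-benzimidazol-2-yl on the formyl-bearing core gives a 1.2-fold higher number from compound 3 to compound 4 (0.08 log units; within the scatter), so the penalty seen on the cyano-bearing core did not carry over in size: the same change on two cores in this assay, a 3.8-fold higher number (0.58 log units; beyond the scatter) from compound 2 to compound 1 and a 1.2-fold higher number (0.08 log units; within the scatter) from compound 3 to compound 4, 3.2-fold (0.51 log units) apart, beyond the scatter of two such steps. Read along the other edge of the same four compounds, formyl in place of cyano on the difluoro-bearing core gives a 1.9-fold higher number from compound 1 to compound 4 (0.29 log units; within the scatter), and this step too differs from its counterpart on the dichloro-bearing core: the same change on two cores in this assay, a 6.2-fold higher number (0.79 log units; beyond the scatter) from compound 2 to compound 3 and a 1.9-fold higher number (0.29 log units; within the scatter) from compound 1 to compound 4, 3.2-fold (0.51 log units) apart, beyond the scatter of two such steps. These two comparisons are one observation seen from two sides: in this set the two changes do not add up independently, so the size of either step depends on the group at the other place, but a single square of compounds gives no rule for other cores and does not show what lies behind the difference.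

The compounds shown leave open whether an acetyl group or a primary amide on the aromatic carbon would behave like the cyano pair or the formyl pair. They also leave open whether a 5,6-dibromo or 5,6-dimethyl benzimidazole, or a longer chain on the amine nitrogen, would show the same dependence.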